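The source may report more compounds than this note shows. Statements on the series, on what has been measured and on what is new or still open speak of the compounds shown alone.

Measured compounds:
compound 1, `COc1ccc(SCc2ccc(/C=C/C(=O)Nc3ccccc3N)cc2)cc1OC`, 49.5%
compound 2, `Nc1ccccc1NC(=O)c1ccc(CSc2cccc(F)c2)cc1`, 81.4%
compound 3, `COC(=O)c1ccccc1SCc1ccc(C(=O)Nc2ccccc2N)cc1`, 92%

In a functional assay on HCT-116 cells (Homo sapiens) for inhibition, read by CCK-8 assay, with a stated time of 72 h, tested at 8 uM (a lower number here means less inhibition of growth, a higher number more inhibition of growth at the concentration tested), compound 1 gives 49.5%, the lowest of the three numbers in hand. Compound 2 gives 81.4%, and compound 3 gives 92%; both of these stand higher than the number for compound 1 by a margin beyond the usual scatter, so compound 1 is the weakest of the three on this read-out. Compound 2 and compound 3 share a core that differs from that of compound 1, so their numbers say little about the part of compound 1 that is varied next.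

The step to be followed leads from compound 1 to compound 4, `CC(C)(C)c1ccc(SCc2ccc(/C=C/C(=O)Nc3ccccc3N)cc2)cc1`, which has not yet been tested in this assay. The change is 4-(tert-butyl)phenyl in place of 3,4-dimethoxyphenyl on a sulfur. Within the data shown here, no measured pair in this set differs in a comparable way, so there is no step on which to anchor the direction. The account therefore rests on compound 1 alone, taken as the starting point, and the expectation is a step of modest size, with a slight lean toward more inhibition of growth rather than less, and a wide band of uncertainty. The expected step is a number 6.5 percentage points higher from compound 1 to compound 4 (within the scatter). For compound 4 the estimate in this assay is 56%, within a range from 32% to 80%.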

Compound 4, percent growth inhibition at one concentration: 39%
For compound 4 the middle estimate is 17 percentage points above the measured one, within the range that was stated.
By their numbers in this assay, from the lowest: compound 4; then compound 1; then compound 2; then compound 3.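

Among these compounds, the pair gives the first direct reading on the group carried on the sulfur: in this assay, 4-(tert-butyl)phenyl in place of 3,4-dimethoxyphenyl comes with a number 10.5 percentage points lower from compound 1 to compound 4 (beyond the scatter), so the number does respond to a change at this position. The two groups have the same count of heavy atoms and each holds one six-membered aromatic ring of carbon only, but 3,4-dimethoxyphenyl carries 2 hydrogen-bond acceptors and 4-(tert-butyl)phenyl carries 0, and this difference travels with the lower number in this one pair. Nothing in hand gives a reason for the step.

The compounds shown leave open which part of the exchange matters, since the removal of the two methoxy groups and the arrival of the tert-butyl group are joined in one step, and a phenyl carrying a single methoxy group or an amine would be needed to pull them apart. Going by these compounds, it also remains open whether the same exchange would move the number in the same direction on the core of compound 2 or compound 3, neither of which forms a one-place pair with compound 1 or compound 4.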